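This account rests on a few compounds, and the source may have more. Where it says the series, first, only, none or still open, it means among the compounds named here.

Working notes on the series.

Compound 1 `C/C(=N/NC(=S)Nc1ccccc1F)c1ccccn1` and compound 2 `C/C(=N/NC(=S)Nc1ccccc1I)c1ccccn1` share the core of compound 1 and differ only in fluoro in place of iodo on an aromatic carbon. In a functional assay on U-87MG ATCC cells (Homo sapiens) for cytotoxicity, read by MTT assay, with a stated time of 48 h (on this read-out lower numbers stand for stronger inhibition and higher numbers for weaker inhibition), compound 1 gives 5 nM, and compound 2 gives 6.1 nM; the step is a 1.2-fold lower number from compound 2 to compound 1 (0.09 log units; within the scatter), so these two values are read as equivalent.

Compound 3 `C/C(=N/NC(=S)Nc1cccc(I)c1)c1ccccn1` has the same atoms as compound 2, joined differently; the difference between the two cores is not broken down here. In this assay compound 3 gives 84 nM, the highest number of the three measured compounds, with compound 2 nearest and compound 1 furthest, both gaps beyond the scatter.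

Compound 4 `C/C(=N/NC(=S)Nc1cccc(F)c1)c1ccccn1` is still to be measured. It differs from compound 3 by fluoro in place of iodo on an aromatic carbon. This is the same kind of change as from compound 2 to compound 1, but not the same: there the group sits ortho to a large group, here meta to a large group. Among the measured compounds shown here, with only one matched pair in hand, the working expectation is that the exchange again moves the number little, because the step of a 1.2-fold lower number from compound 2 to compound 1 (0.09 log units; within the scatter) stayed within the scatter, and the step expected here is a 1.1-fold lower number from compound 3 to compound 4 (0.05 log units; within the scatter). Compound 4 is therefore expected to land near the value of compound 3 84 nM in this assay. The estimate for compound 4 is 75 nM, with a range from 30 nM to 200 nM.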

Compound 4, half-maximal inhibitory concentration: 18 nM
Compound 4: middle estimate off by 4.2-fold (0.62 log units), on the high side; the whole stated range lies above it.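

In this assay, fluoro in place of iodo on an aromatic carbon, here meta to a large group, gives a 4.7-fold lower number from compound 3 to compound 4 (0.67 log units; beyond the scatter), and this step does not match the earlier one: the same change on two cores in this assay, a 1.2-fold lower number (0.09 log units; within the scatter) from compound 2 to compound 1 and a 4.7-fold lower number (0.67 log units; beyond the scatter) from compound 3 to compound 4, 3.8-fold (0.58 log units) apart, beyond the scatter of two such steps The same exchange therefore stays within the scatter on the core of compound 1 and goes beyond it on the core of compound 3, so in this series the size of the step read on one core cannot simply be carried over to the other. Among the compounds shown here, this does not show what sets the two steps apart, and with only two matched pairs in a single cell assay it gives no rule for any further core, nor any reason to expect the same gap on another read-out.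

The compounds shown leave open whether the gap between the two cores is particular to the exchange of iodo and fluoro or also appears with other groups at the same places, such as chloro, bromo, methyl or methoxy. They also leave open how a group of another kind, such as an amine or a carboxylic acid, would behave on either core in this assay.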